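The source may hold more compounds than are shown below. What is called first, only, known or untested is meant among the compounds shown, and "the series" means these compounds.

Measured so far:
compound 1, `CCn1ncnc1-c1ccccc1NCC1=NCCN1`, a functional assay with Alpha-1B adrenergic receptor (Homo sapiens) as the target, read by calcium flux; a higher number here means a larger maximal response, a lower number a smaller maximal response: 94%
compound 2, `CCCCn1ncnc1-c1ccccc1NCC1=NCCN1`, this assay: 83%
compound 3, `Cn1cc(-c2ccccc2NCC2=NCCN2)cn1`, this assay: 0%

Compound 2 stands second highest of the three values; compound 1 lies above it by a step beyond the scatter, and compound 3 lies far below it, also beyond the scatter. Compound 4, `CCCn1ncnc1-c1ccccc1NCC1=NCCN1`, has not yet been measured in this assay. From compound 2 to compound 4 the change is hydrogen in place of methyl on a saturated chain carbon, three bonds along the chain from an aromatic nitrogen, the same difference that, cut one bond further out, reads butyl to propyl.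

For the measured compounds named here, one measured step bears on this: a number 11 percentage points lower from compound 1 to compound 2 (beyond the scatter), where a longer chain went with a modestly lower maximal response. Compound 4 carries a chain of intermediate length, so a small move back toward compound 1 is expected, but not one clearly beyond the scatter. Compound 4 is therefore estimated at 88%, with a range from 76% to 99%. The expected step is a number 5 percentage points higher from compound 2 to compound 4 (within the scatter).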

Compound 4, largest response reached (reported as maximal response), in percent of the reference or control that the assay uses: 74%
Compound 4: the middle estimate sits 14 percentage points above what was measured; measured number outside the range, below it.
By their numbers in this assay, from the lowest: compound 3; then compounds 4 and 2 (each within the scatter of the next); then compound 1.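

In this assay, the exchange of butyl for propyl at this place gives a number 9 percentage points lower from compound 2 to compound 4 (within the scatter) and so does not separate the two chains. The propyl chain nevertheless stands apart from the ethyl chain, with a number 20 percentage points lower from compound 1 to compound 4 (beyond the scatter) as the second step, which shows that among these three compounds the response does not follow chain length in a steady line: the ethyl chain of compound 1 stands clear of both longer chains, which themselves lie within the scatter of each other. No measurement at hand accounts for this result.

As far as these compounds go, what a pentyl chain or a branched isopropyl group would give at this place stays open. So does the effect of a hydroxyl group on the chain.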